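This account rests on a few compounds, and the source may have more. Where it says the series, first, only, none or still open, it means among the compounds named here.

Working notes on the series. In a functional assay on Maver1 cells (Homo sapiens) for inhibition, read by luminescence and CellTiter-Glo, with a stated time of 72 h (on this read-out lower numbers stand for stronger inhibition and higher numbers for weaker inhibition), compound 1 `C=CC(=O)Nc1ccc(Cn2nc(-c3ccc(Oc4ccccc4)cc3)cc2C(=O)OCC)cc1` gives 13300 nM. Compound 2 `C/C=C/C(=O)Nc1ccc(Cn2nc(-c3ccc(Oc4ccccc4)cc3)cc2C(=O)OCC)cc1` differs from it only at the carbonyl carbon, prop-1-en-1-yl in place of vinyl, and an at least 4.5-fold higher number from compound 1 to compound 2 (0.65 log units; beyond the scatter). For compound 2 this assay returns only a limit, > 60000 nM, not a number. Compound 3 `C/C=C/C(=O)Nc1ccc(Cn2nc(-c3ccc(Oc4ccccc4)cc3)cc2CO)cc1`, with hydroxymethyl in place of ethoxycarbonyl on an aromatic carbon, gives 48400 nM, and an at least 1.2-fold lower number from compound 2 to compound 3 (0.09 log units; that floor lies within the scatter). That floor says little because the limit of > 60000 nM in this assay, at which 1 of the 3 values shown sits, is where compound 2 sits. On the numbers shown compound 2 therefore stands only as a limit, without a value of its own.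

Compound 4 `C=CC(=O)Nc1cccc(Cn2nc(-c3ccc(Oc4ccccc4)cc3)cc2C(=O)OCC)c1` is reached from compound 2 by 3-((vinylcarbonyl)amino)phenyl in place of 4-(((prop-1-en-1-yl)carbonyl)amino)phenyl on a saturated chain carbon bound to an aromatic nitrogen. The change undoes the swap from vinyl to prop-1-en-1-yl and at the same time alters the phenyl from 4-(((prop-1-en-1-yl)carbonyl)amino)phenyl to 3-((vinylcarbonyl)amino)phenyl. Only the first part has a measured counterpart, an at least 4.5-fold higher number from compound 1 to compound 2 (0.65 log units; beyond the scatter), which ran the other way. Among the compounds with values here, no measured pair separates the two phenyl patterns. A lower number is therefore expected, a step of about an at least 3.0-fold lower number from compound 2 to compound 4 (0.47 log units; beyond the scatter), with wide uncertainty. Compound 4 is estimated to give around 20000 nM in this assay, between 5000 nM and 80000 nM.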

Compound 4, half-maximal inhibitory concentration: 8600 nM
Compound 4: middle estimate off by 2.3-fold (0.37 log units), on the high side; measured number inside the range.
By their numbers in this assay, from the lowest: compounds 4 and 1 (each within the scatter of the next); then compound 3. At a limit, above all of these: compound 2.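

The phenyl pattern can now be read on its own, with 3-((vinylcarbonyl)amino)phenyl in place of 4-((vinylcarbonyl)amino)phenyl on a saturated chain carbon bound to an aromatic nitrogen: in this assay this pair shows a 1.5-fold lower number from compound 1 to compound 4 (0.19 log units; within the scatter). The two-part change is larger, an at least 6.9-fold lower number from compound 2 to compound 4 (0.84 log units; beyond the scatter), and with the phenyl swap alone within the scatter, the size of this step goes with the return from prop-1-en-1-yl to vinyl and not with the phenyl pattern. Compound 2 remains a limit and not a number, so this step is a floor only: the limit of > 60000 nM in this assay, at which 1 of the 4 values shown sits.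

Still open, going by these compounds, is whether prop-1-en-1-yl in place of vinyl on the carbonyl carbon gives a similar step when the phenyl carries its amide as in compound 4, and how hydroxymethyl in place of ethoxycarbonyl reads with vinyl on the carbonyl carbon. Also open, on these data alone, is how a propanoyl group on the amide nitrogen, or a carboxylic acid in place of ethoxycarbonyl on the aromatic carbon, would read.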